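Exchanging the aryl group on the shared core

The source may report more compounds than this note shows. Statements on the series, on what has been measured and on what is new or still open speak of the compounds shown alone.

Compound 2 `CC(C)(C)Cc1c(-c2c(F)cccc2F)sc(N)c1C(=O)c1ccc(Cl)cc1` stands lowest of the two numbers seen in an assay on CHO cells for displacement of a labelled ligand from adenosine receptor A3 (Homo sapiens), read by scintillation counting, tested at 10 uM (on this read-out lower numbers stand for less inhibition and higher numbers for more inhibition at the one concentration tested (going by the name of the read-out)), where compound 2 gives 1%; compound 1 `CC(C)(C)Cc1csc(N)c1C(=O)c1ccc(Cl)cc1` gives 5%, and the step of a number 4 percentage points lower from compound 1 to compound 2 (within the scatter) lies within the scatter. Compound 3 `Cc1ccccc1-c1sc(N)c(C(=O)c2ccc(Cl)cc2)c1CC(C)(C)C` differs from compound 2 by 2-methylphenyl in place of 2,6-difluorophenyl on an aromatic carbon. Going by the values given here, no measured step covers this exact exchange; the one step seen, a number 4 percentage points lower from compound 1 to compound 2 (within the scatter), shows that changing the group on that aromatic carbon did not move the read-out beyond the scatter. Compound 3 is therefore expected to show no step beyond the scatter, a number 2 percentage points higher from compound 2 to compound 3 (within the scatter), with an estimated value of 3% and a range from 0% to 15%.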

Compound 3, a percentage reported as inhibition, at one concentration (the size of the read-out at that concentration, not a potency): 1%
Beside the measured number, compound 3's estimate is 2 percentage points above it; measured number inside the range.
By their numbers in this assay, from the lowest: compounds 2, 3 and 1 (each within the scatter of the next).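

In this assay 2-methylphenyl in place of 2,6-difluorophenyl gives no change at the digits printed from compound 2 to compound 3 (within the scatter) and 2-methylphenyl in place of hydrogen gives a number 4 percentage points lower from compound 1 to compound 3 (within the scatter) so that, on this aromatic carbon next to the ring sulfur, a second kind of aryl group also leaves the read-out within the scatter of the parent. The result therefore does not depend on the fluorine atoms alone. No evidence bears on why this is so. As far as these compounds go, whether an amine, a carboxylic acid or a longer chain on this carbon would move the read-out stays open.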